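Aryl substituent swap at the piperazine phenyl: chloro to trifluoromethyl

The compounds below may be only part of what the source reports. "The series", "measured", "known", "first", "only" and "open" are said of these compounds alone.

Of the compounds shown here, three have been measured in an assay on HEK293 cells for inhibition of Voltage-dependent T-type calcium channel subunit alpha-1G (Homo sapiens), read by fluorescence, tested at 10 uM; on this read-out higher numbers stand for more inhibition at the one concentration tested (going by the name of the read-out) and lower numbers for less inhibition. Compound 1 `CCCc1nc(-c2ccccc2)c(CNCCN2CCN(c3ccc(Cl)cc3)CC2)o1` gives 55.8%. Compound 2 `CCCc1nc(-c2ccccc2)c(CNCCN2CCN(c3cccc(C(F)(F)F)c3)CC2)o1` gives 56.3%. Compound 3 `CCCc1nc(-c2ccccc2)c(CNCCN2CCN(c3ccccc3Cl)CC2)o1` gives 60.1%. The three numbers sit close together: a number 4.3 percentage points higher from compound 1 to compound 3 (within the scatter) and a number 3.8 percentage points higher from compound 2 to compound 3 (within the scatter), so compound 3 is not separated from either of the other two.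

Compound 4 `CCCc1nc(-c2ccccc2)c(CNCCN2CCN(c3ccccc3C(F)(F)F)CC2)o1` differs from compound 3 by trifluoromethyl in place of chloro on an aromatic carbon. The closest measured comparison is a number 0.5 percentage points higher from compound 1 to compound 2 (within the scatter), which also exchanges a chloro-bearing phenyl for a trifluoromethyl-bearing one, though at a different position on the ring. All three measured steps lie within the scatter, including a number 4.3 percentage points higher from compound 1 to compound 3 (within the scatter), so none of them gives grounds for expecting a move beyond the scatter here.

Compound 4 is therefore expected to come out close to compound 3, with an estimated step of a number 2.1 percentage points lower from compound 3 to compound 4 (within the scatter). The estimate for compound 4 in this assay is 58%, with a range from 45% to 71%.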

Compound 4, a percentage reported as inhibition, at one concentration (the size of the read-out at that concentration, not a potency): 54.6%
Estimate against measurement, compound 4: 3.4 percentage points above; the measured number falls inside the stated range.
By their numbers in this assay, from the lowest: compounds 4, 1, 2 and 3 (each within the scatter of the next).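

Working notes: in this assay, the first exchange of chloro for trifluoromethyl at a single place on the phenyl ring gives a number 5.5 percentage points lower from compound 3 to compound 4 (within the scatter), so going from one heavy atom to four on this aromatic carbon does not separate the pair. The 2-(trifluoromethyl)phenyl group also stays unseparated from the two other aryl groups, with a number 1.7 percentage points lower from compound 2 to compound 4 (within the scatter) and a number 1.2 percentage points lower from compound 1 to compound 4 (within the scatter), so all four compounds remain within the scatter of the next in line and no substituent or placement stands apart. No measured evidence bears on the reason for this result.

Still open, going by these compounds, is whether a methoxy group, a nitrile or an amine at this place on the phenyl ring would give a step beyond the scatter. On these data alone, the effect of a longer chain in place of the propyl group on the core also remains open.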